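A few compounds are considered here, and "the series" means these few. Any claim that something is new, unique, unknown or untested is made for them only; others in the source may bear on it.

Measured so far:
compound 1, `Cc1cnc(CN2CC(=O)N(CC(C)C)c3c(Cl)nc(N)nc32)c(C)c1Br`: 140 nM
compound 2, `COc1c(C)cnc(CN2c3nc(N)nc(Cl)c3NC(=O)[C@H]2C)c1C`: 470 nM
compound 3, `COc1c(C)cnc(CN2c3nc(N)nc(Cl)c3NC(=O)[C@@H]2C)c1C`: 660 nM

In a functional assay on HT-29 cells (Homo sapiens) for inhibition (on this read-out higher numbers stand for weaker inhibition and lower numbers for stronger inhibition), compound 3 stands at the high end of the three numbers: its value and that of compound 2 lie within the scatter of each other, while compound 1 lies well below it, beyond the scatter. Within the data shown here, the only measured step that touches compound 3 is a 1.4-fold higher number from compound 2 to compound 3 (0.15 log units; within the scatter), and that pair differs in nothing but configuration (the fact that compounds 2 and 3 differ only in the configuration as drawn), so it says nothing about adding carbon to the chain. Compound 4, `COc1c(C)cnc(CN2c3nc(N)nc(Cl)c3NC(=O)[C@@H]2CC(C)C)c1C`, differs from compound 3 by isopropyl in place of hydrogen on a saturated chain carbon bound to a saturated ring carbon. Among the measured compounds shown here, no measured pair shows this difference; compound 1 carries an isobutyl on a different atom within a different core, and no step between it and compound 3 is drawn, so only its value speaks. For the measured compounds named here, with no directly comparable step in this assay, compound 4 is expected to stay near compound 3, with a wide range around it: a 1.3-fold lower number from compound 3 to compound 4 (0.12 log units; within the scatter) is the expected step. Compound 4 is thus estimated at 500 nM, between 150 nM and 1600 nM.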

Compound 4, half-maximal inhibitory concentration: 690 nM
Compound 4: the middle estimate sits 1.4-fold (0.14 log units) below what was measured; measured number inside the range.
By their numbers in this assay, from the lowest: compound 1; then compounds 2, 3 and 4 (each within the scatter of the next).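

In this assay the measured change is a 1.0-fold higher number from compound 3 to compound 4 (0.02 log units; within the scatter) and so replacing methyl with isobutyl at this place, on the saturated ring carbon that already carried the methyl, leaves the read-out unable to tell the two apart. Among these compounds, the earlier step at this carbon concerned configuration alone, so this is the first reading of what a change in the group itself does there, and a branched chain proves compatible with the level of inhibition seen for compound 3. Nothing measured here offers a reason for this flat result.

As far as these compounds go, whether an amine, a carboxylic acid or a longer chain at this place would read the same remains open. So does whether configuration at this carbon counts once isobutyl is present.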